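This account rests on a few compounds, and the source may have more. Where it says the series, first, only, none or still open, it means among the compounds named here.

Measured compounds in a toxicity assay on Huh-7.5 cells (Homo sapiens) for inhibition, read by MTT assay, with a stated time of 96 h; on this read-out lower numbers stand for higher toxicity in this test and higher numbers for lower toxicity in this test:
compound 1 `CN1CCN(Cc2ccc(NC(=O)c3ccc(OCCCCl)c(Cl)c3)cc2C(F)(F)F)CC1`: 4100 nM
compound 2 `CC(C)Oc1ccc(C(=O)Nc2ccc(N(C)C)cc2)cc1[N+](=O)[O-]`: 50000 nM
compound 3 `COc1ccc(C(=O)Nc2cc(OC)c(OC)c(OC)c2)cc1NC(=O)C(C)Br`: 15000 nM

Among the three numbers, compound 1 stands lowest, that is, it is the most toxic of the set in this assay. Compound 3 is nearest to it, with a higher number that lies beyond the scatter, and compound 2 is furthest, with a higher number that also lies beyond the scatter. No two of these compounds differ in only one place, so no step between measured compounds can be followed.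

Compound 4 `CN1CCN(Cc2ccc(NC(=O)c3ccc(OCCCCl)c([N+](=O)[O-])c3)cc2C(F)(F)F)CC1` has not yet been measured in this assay. It is related to compound 1 by a single change: nitro in place of chloro on an aromatic carbon. Nothing in the measured set shows what this particular change does to the read-out on this scaffold. Without such a precedent, the step from compound 1 to compound 4 is expected to be small, probably not beyond the scatter, with a slight lean toward a higher number, the estimate being a 1.5-fold higher number from compound 1 to compound 4 (0.17 log units; within the scatter). Compound 4 is therefore expected to give about 6000 nM, within a range of 2500 nM to 15000 nM.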

Compound 4, half-maximal cytotoxic concentration: 6800 nM
For compound 4 the middle estimate is 1.1-fold (0.05 log units) below the measured one; the measured number falls inside the stated range.
By their numbers in this assay, from the lowest: compounds 1 and 4 (each within the scatter of the next); then compound 3; then compound 2.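

In this assay, nitro in place of chloro on the aromatic carbon ortho to the 3-chloropropoxy group and meta to a large group gives a 1.7-fold higher number from compound 1 to compound 4 (0.22 log units; within the scatter). Within the data shown here, this is the first single change that can be followed in the set, and it shows that at this position on the core of compound 1, the read-out does not tell nitro and chloro apart, so the toxicity seen in this test does not depend on chloro being present there. No measurement offered here explains this result.

As far as these compounds go, whether an amine or a carboxylic acid at the same position would also stay within the scatter remains open. So does the part played by the 3-chloropropoxy group, since the compounds shown include no step to a longer chain or a hydroxyl at that place.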